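Swapping the Aryl Group on a Urea Linker

The source may hold more compounds than are shown below. What is called first, only, known or untested is meant among the compounds shown, and "the series" means these compounds.

Measured compounds:
Compound 1, `O=C(Nc1ccc(Cl)cc1)N[C@H]1CC[C@H](Oc2ccc(F)cc2)CC1`: > 20000 nM
Compound 2, `O=C(Nc1cccc(C(F)(F)F)c1)N[C@H]1CC[C@H](Oc2ccc(OC(F)(F)F)cc2)CC1`: 690 nM

Both measured compounds share a core in which a urea joins a substituted phenyl group to a cyclohexane ring carrying an aryl ether. In a functional assay on CRL2813 cells (Homo sapiens) for cytotoxicity, read by sulforhodamine B assay, with a stated time of 5 days (a lower number here means a stronger inhibitor, a higher number a weaker inhibitor), compound 1 reaches only the limit of the assay, > 20000 nM, so no number is known for it. Among the measured compounds shown here, compound 2 gives 690 nM in this assay; it differs from compound 1 in both aryl groups, so the two values show only that the pair lies far apart.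

Compound 3, `CSc1cccc(NC(=O)N[C@H]2CC[C@H](Oc3ccc(F)cc3)CC2)c1`, has not yet been measured. It keeps the aryl ether side of compound 1 and changes the other end: 3-(methylsulfanyl)phenyl in place of 4-chlorophenyl on an amide-type nitrogen. As compound 1 stands at the limit (the limit of > 20000 nM in this assay, at which 1 of the 2 values shown sits), the starting point of this step has no number. Compound 3 is expected to give about 8000 nM, within 1500 nM to 25000 nM. The step from compound 1 to compound 3 is thus estimated at an at least 2.5-fold lower number from compound 1 to compound 3 (0.39 log units; beyond the scatter), with a fair chance that this assay again reports only a limit.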

Compound 3, half-maximal inhibitory concentration: 11100 nM
Estimate against measurement, compound 3: 1.4-fold (0.14 log units) below; the range from low to high includes it.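

With the aryl ether side of compound 1 kept in place, compound 3 gives 11100 nM in this assay, which provides a measured number for this core to compare later changes against. Putting 3-(methylsulfanyl)phenyl in place of 4-chlorophenyl on the amide-type nitrogen gives an at least 1.8-fold lower number from compound 1 to compound 3 (0.25 log units; that floor lies within the scatter), so this single change cannot yet be told apart from the usual scatter. The true size of the step stays unknown because compound 1 has no number of its own, only a limit: the limit of > 20000 nM in this assay, at which 1 of the 3 values shown sits.

The groups 4-chlorophenyl and 3-(methylsulfanyl)phenyl differ both in the substituent and in the number in their names, and the compounds shown do not separate these two differences. Also open, on these data alone, is how this core would read in this assay with a simple amine or a carboxylic acid on that phenyl ring, or with a longer chain on the sulfur in place of its methyl group.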